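The compounds below may be only part of what the source reports. "The series", "measured", "known", "first", "only" and "open" are said of these compounds alone.

Working notes on the series. The series shares one core, varied only at the amide carbonyl. Compound 1 `CC(Cl)CC(=O)NC1=C(C#N)C(c2ccc(Cl)cc2Cl)C2=C(CCCC2=O)N1c1ccc(S(N)(=O)=O)cc1` carries a 2-chloropropyl there; in a functional assay on Ehrlich cells (Mus musculus) for cytotoxicity, read by trypan blue exclusion, with a stated time of 2 h, tested at 25 ug/mL (on this read-out higher numbers stand for a stronger effect at the one concentration tested and lower numbers for a weaker effect), compound 1 gives 50%. Compound 2 `N#CC1=C(NC(=O)C2CC2)N(c2ccc(S(N)(=O)=O)cc2)C2=C(C(=O)CCC2)C1c1ccc(Cl)cc1Cl` carries a cyclopropyl; in this assay compound 2 gives 40%. Compound 3 `Cc1ccc(C(=O)NC2=C(C#N)C(c3ccc(Cl)cc3Cl)C3=C(CCCC3=O)N2c2ccc(S(N)(=O)=O)cc2)cc1` carries a 4-methylphenyl; in this assay compound 3 gives 30%. On the numbers in hand compound 3 stands lowest of the three, with compound 2 nearest (a number 10 percentage points lower from compound 2 to compound 3 (within the scatter)) and compound 1 furthest (a number 20 percentage points lower from compound 1 to compound 3 (beyond the scatter)); the step of a number 10 percentage points lower from compound 1 to compound 2 (within the scatter) is the remaining measured step.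

Compound 4 `N#CC1=C(NC(=O)c2ccc([N+](=O)[O-])cc2)N(c2ccc(S(N)(=O)=O)cc2)C2=C(C(=O)CCC2)C1c1ccc(Cl)cc1Cl` differs from compound 3 in one place: nitro in place of methyl on an aromatic carbon. Going by the values given here, none of the measured steps touches this position; all three concern exchange of the whole acyl group, and the largest of them, a number 20 percentage points lower from compound 1 to compound 3 (beyond the scatter), is modest. The exchange of a substituent on the aryl ring is a smaller move than any measured step, so for compound 4 no step beyond the scatter in this assay is expected, and compound 4 is estimated at 30%, within 15% to 50%. The expected step from compound 3 is no change at the digits printed from compound 3 to compound 4 (within the scatter).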

Compound 4, a percentage reported as activity, at one concentration (the size of the read-out at that concentration, not a potency): 40%
The estimate for compound 4 lay 10 percentage points below the measured number; the measured number falls inside the stated range.
By their numbers in this assay, from the lowest: compounds 3, 2, 4 and 1 (each within the scatter of the next, the first and the last beyond it).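

Going by these compounds alone, this is the only step that changes a substituent on the aryl ring rather than the whole acyl group: in this assay there is a number 10 percentage points higher from compound 3 to compound 4 (within the scatter) for nitro in place of methyl, para to a large group, so this exchange is not resolved from no change on this read-out. The acyl comparisons give no change at the digits printed from compound 2 to compound 4 (within the scatter) and a number 10 percentage points lower from compound 1 to compound 4 (within the scatter), whereas the earlier series held a number 20 percentage points lower from compound 1 to compound 3 (beyond the scatter), so a separation from the 2-chloropropyl amide does not hold for both aryl amides, and compound 4 is separated from none of the other three compounds. No measurement is available that bears on the origin of these numbers.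

On these data alone, with only methyl and nitro at this aromatic carbon, it remains open whether an amine or a carboxylic acid there would take the number in this assay beyond the scatter from compound 3 or compound 4. Also open, as far as these compounds go, is how a longer chain on the carbonyl carbon would compare with the 2-chloropropyl of compound 1, and these readings at one concentration give no potency for any of the four compounds.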